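Phenyl for 2-(methylamino)ethyl in compound 3

This account rests on a few compounds, and the source may have more. Where it says the series, first, only, none or still open, it means among the compounds named here.

In a functional assay on HCT-116 cells (Homo sapiens) for cytotoxicity, read by MTT assay, with a stated time of 72 h (on this read-out lower numbers stand for stronger inhibition and higher numbers for weaker inhibition), compound 2 `CNCCCNc1c(C(=O)NCc2ccc(F)cc2)nc(Br)c2cccnc12` reads > 10000 nM, which is only a limit. Compound 1 `O=C(NCc1ccc(F)cc1)c1nc(Br)c2cccnc2c1NCc1ccc(F)cc1` reads > 20000 nM, also a limit. Compound 3 `O=C(NCc1ccc(F)cc1)c1nc(Br)c2cccnc2c1NCc1ccccc1` carries phenyl in place of 2-(methylamino)ethyl on a saturated chain carbon bound to a nitrogen on an aromatic ring. Going by the values given here, the one measured step bearing on this is a step that the two limits leave unreadable from compound 1 to compound 2, which exchanged 4-fluorophenyl for 2-(methylamino)ethyl at that place. With no readable size to carry over, only a small weakening or none is expected in this assay, and the expected step is a step that the limit leaves unreadable from compound 2 to compound 3. For compound 3 the estimate is 25000 nM, with a range from 10000 nM to 60000 nM.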

Compound 3, half-maximal inhibitory concentration: > 20000 nM
Compound 3: only a limit was reported (the forecaster's own chance of this, stated with the estimate: 80%); the middle value is on the limit's open side.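

Going by these compounds alone, compound 1, compound 2 and compound 3 are all reported only as limits, and no step among them can be read. The compounds shown leave open whether any of these exchanges changes cytotoxicity at all.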